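A few compounds are considered here, and "the series" means these few. Any claim that something is new, unique, unknown or untested is made for them only; others in the source may bear on it.

Of the compounds shown here, two from this series have been measured in a functional assay, with a stated time of 150 min, tested at 30 ug/mL; on this read-out higher numbers stand for a stronger effect at the one concentration tested and lower numbers for a weaker effect. Compound 1, with the structure `COC(=O)c1c(Nc2ccc(C)cc2)sc(C(=O)c2ccc(OC)cc2)c1C`, is reported as "not active" (no number reported), and no number stands beside that entry. Compound 2, with the structure `COC(=O)c1c(Nc2ccc(F)cc2)sc(C(=O)c2ccc(OC)cc2)c1C`, gives 23.3% in this assay. Compound 2 therefore holds the only number shown so far, with one further entry that carries no single number, so its place cannot be compared to any other value.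

The next compound, compound 3, has the structure `COC(=O)c1c(Nc2ccc(Cl)cc2)sc(C(=O)c2ccc(OC)cc2)c1C`. Compared with compound 2 it differs in one place: chloro in place of fluoro on an aromatic carbon. Both groups are single heavy atoms on an aromatic carbon, and nothing is added or removed in the way of rings, hydrogen-bond donors or acceptors, or charge.

Within the data shown here, no measured pair shows what such a swap does in this assay, so there is no step to lean on. The expectation is a step in this assay that stays within the usual scatter, perhaps leaning slightly upward, estimated as a number 4.7 percentage points higher from compound 2 to compound 3 (within the scatter) from compound 2 to compound 3. Compound 3 is accordingly expected to give about 28%, with a likely range from 10% to 50%.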

Compound 3, a percentage reported as activity, at one concentration (the size of the read-out at that concentration, not a potency): "not active" (no number reported)
Compound 3: no number reported; the estimate stays without a comparison.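

In this assay, among these compounds, compound 3 is entered as "not active" (no number reported) and so, with no number to set against that of compound 2, no step between the two can be read. Nothing measured here offers an explanation for this entry. The compounds shown leave open how a 4-chlorophenyl group compares in size of effect with a 4-fluorophenyl group on this core.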